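The source may hold more compounds than are shown below. What is called first, only, known or untested is meant among the compounds shown, and "the series" means these compounds.

Measured compounds:
Compound 1, `O=c1[nH]c(=S)ccn1[C@@H]1O[C@H](COP(=O)(O)O)[C@@H](O)[C@H]1O`: > 100000 nM
Compound 2, `CCCSc1nc(=O)ccn1[C@@H]1O[C@H](COP(=O)(O)OP(=O)(O)O)[C@@H](O)[C@H]1O`: 4900 nM

In an in vitro functional assay on 1321-N1 cells for agonist activity at P2Y purinoceptor 4 (Homo sapiens), read by scintillation proximity assay and inositol phosphate accumulation (on this read-out higher numbers stand for an effect only at larger amounts of compound and lower numbers for an effect already at smaller amounts), compound 1 gives > 100000 nM, which is a limit of the assay rather than a number; of the two values in hand, (the limit of > 100000 nM in this assay, at which 1 of the 2 values shown sits). In this assay, going by the values given here, compound 2 gives 4900 nM, the only number reported, so compound 2 stands alone as the single measured point from which a step can be taken.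

Compound 3, `O=c1ccn([C@@H]2O[C@H](COP(=O)(O)OP(=O)(O)O)[C@@H](O)[C@H]2O)c(SCCc2ccccc2)n1`, has not yet been measured. It differs from compound 2 as follows: phenyl in place of methyl on a saturated chain carbon, two bonds along the chain from a sulfur. Among the compounds with values here, no step between two measured compounds exists to guide the size of this change. The expectation for compound 3 is therefore a modest step, a 1.6-fold lower number from compound 2 to compound 3 (0.21 log units; within the scatter), within or near the usual scatter rather than far beyond it. On that basis compound 3 is estimated to give 3000 nM in this assay, with a range from 700 nM to 15000 nM.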

Compound 3, half-maximal effective concentration: >= 100000 nM
Compound 3 ended at the assay's limit (the forecaster's own chance of this, stated with the estimate: 10%); at least 33-fold (1.52 log units) between middle value and limit.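

In this assay, going by these compounds alone, this result gives the first step at this place, for phenyl in place of methyl on a saturated chain carbon, two bonds along the chain from a sulfur: an at least 20-fold higher number from compound 2 to compound 3 (1.30 log units; beyond the scatter). Compound 3 gives >= 100000 nM, which is a limit of the assay and not a number, so the step has a floor but no exact size. In this one pair, the change from propylsulfanyl to phenethylsulfanyl is enough to take the read-out from a measured number to the limit, so this place does not accept every change.

Within the data shown here, with only this one step at this place, it remains open whether a butyl chain or a methoxy group at the end of the chain would keep a measured number in this assay. A cyclohexyl group in place of the phenyl would be needed to show whether the aromatic ring itself matters.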